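The source may hold more compounds than are shown below. What is called first, only, known or untested is meant among the compounds shown, and "the series" means these compounds.

Measured compounds:
- compound 1, `O=C(COc1nnnn1-c1cccc2ccccc12)Nc1ccccc1[N+](=O)[O-]`: 0.05 h
- compound 2, `O=C(CSc1nnnn1-c1cccc2ccccc12)Nc1ccccc1Cl`: 0.1 h
- compound 3, `CN(C(=O)CCC(=O)Nc1ccc(-c2ccc(OCC(=O)O)cc2)cc1Cl)c1ccc(C(C)(C)C)cc1Cl`: 0.9 h

These three were tested in an in vitro ADME assay on microsomes from liver (Homo sapiens) for metabolic stability; on this read-out lower numbers stand for a shorter-lived compound and higher numbers for a longer-lived compound. Among them compound 3 stands highest, with compound 2 nearest and compound 1 furthest; both gaps lie beyond the usual scatter of this assay. Compound 4, `CCN(C(=O)CCC(=O)Nc1ccc(-c2ccc(OCC(=O)O)cc2)cc1Cl)c1ccc(C(C)(C)C)cc1Cl`, has not yet been measured. It differs from compound 3 by methyl in place of hydrogen on a saturated chain carbon bound to an amide-type nitrogen. Going by the values given here, no pair of measured compounds differs by a change of this kind, so nothing measured here shows what such a change does. The expected step from compound 3 to compound 4 in this assay is no change at the digits printed from compound 3 to compound 4 (within the scatter), that is, nothing beyond the scatter in either direction. Compound 4 is therefore estimated at 0.9 h, within a range from 0.4 h to 1.8 h.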

Compound 4, half-life: 0.1 h
Compound 4: middle estimate off by 9.0-fold (0.95 log units), on the high side; measured number below the stated range.
By their numbers in this assay, from the lowest: compounds 1, 2 and 4 (each within the scatter of the next); then compound 3.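

In this assay, this position turns out to be sensitive: methyl in place of hydrogen on a saturated chain carbon bound to an amide-type nitrogen, which can also be read as methyl to ethyl, gives a 9.0-fold lower number from compound 3 to compound 4 (0.95 log units; beyond the scatter) with the rest of the structure unchanged. A single added carbon is therefore enough to shorten the half-life beyond the scatter.

From the compounds shown here alone, whether a longer chain such as propyl, or a hydroxyl group on this chain, would shorten or lengthen the half-life remains open. Nothing available explains the step.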